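This account rests on a few compounds, and the source may have more. Where it says the series, first, only, none or still open, it means among the compounds named here.

Values in a functional assay on SGC-7901 cells (Homo sapiens) for antiproliferative activity, read by MTT assay, with a stated time of 72 h; on this read-out higher numbers stand for weaker inhibition and lower numbers for stronger inhibition:
Compound 1 `COc1cc(-n2cnc3ccc(-c4ccc(C(C)=O)cc4)cc32)cc(OC)c1OC`: 450 nM
Compound 2 `COc1ccc(-c2ccc3ncn(-c4cc(OC)c(OC)c(OC)c4)c3c2)cc1O`: 44 nM
Compound 3 `COc1cc(-n2cnc3ccc(-c4cccc(C)c4)cc32)cc(OC)c1OC`: 1240 nM

Compound 3 has the highest number of the three and is therefore the weakest inhibitor here. Compound 4 `COc1cc(-n2cnc3ccc(-c4ccc(Cl)cc4)cc32)cc(OC)c1OC` differs from compound 3 by one change, 4-chlorophenyl in place of 3-methylphenyl on an aromatic carbon.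

Among the compounds with values here, two measured steps bear on this position. The closer guide is the modest 2.8-fold higher number from compound 1 to compound 3 (0.44 log units; beyond the scatter), where 4-acetylphenyl is the group that leaves. The large 28-fold higher number from compound 2 to compound 3 (1.45 log units; beyond the scatter) involves 3-hydroxy-4-methoxyphenyl and is a weaker guide. The expected change in this assay is a modest move to a lower number, a 1.7-fold lower number from compound 3 to compound 4 (0.22 log units; within the scatter). For compound 4 the estimate is 750 nM, with an expected range of 280 nM to 2000 nM.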

Compound 4, half-maximal inhibitory concentration: 1270 nM
The estimate for compound 4 lay 1.7-fold (0.23 log units) below the measured number; the measured number falls inside the stated range.
By their numbers in this assay, from the lowest: compound 2; then compound 1; then compounds 3 and 4 (each within the scatter of the next).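

With a 1.0-fold higher number from compound 3 to compound 4 (0.01 log units; within the scatter), 3-methylphenyl and 4-chlorophenyl cannot be told apart at this position, though both the substituent and its place on the ring differ. Chloro in place of acetyl gives a 2.8-fold higher number from compound 1 to compound 4 (0.45 log units; beyond the scatter), matching the gap already seen for compound 3, while a 29-fold higher number from compound 2 to compound 4 (1.46 log units; beyond the scatter) shows that 3-hydroxy-4-methoxyphenyl remains far apart from this group too. Nothing available explains these steps. Still open, going by these compounds, is how an amine or a carboxylic acid on this phenyl ring would compare with chloro and acetyl.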